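Replacing the azetidin-3-yl group of compound 1

The compounds below may be only part of what the source reports. "The series", "measured", "known", "first", "only" and "open" are said of these compounds alone.

In a functional assay on Ishikawa cells (Homo sapiens) for antiproliferative activity, read by CCK-8 assay, with a stated time of 48 h (a lower number here means a stronger inhibitor, a higher number a weaker inhibitor), compound 1 (`C/C=C/C(=O)N1CC(Oc2ccc(Oc3c(-c4ccc(F)cc4)sc4cc(O)ccc34)cc2)C1`) gives 9400 nM and compound 2 (`O=C(/C=C/CN1CC(Oc2ccc(Oc3c(-c4ccc(F)cc4)sc4cc(O)ccc34)cc2)C1)N1CCCC1`) gives 9150 nM while compound 3 (`O=C(/C=C/CN1CC(Oc2ccc(Oc3c(-c4ccc(F)cc4)sc4cc(O)ccc34)cc2)C1)N1CCC1`) gives 5450 nM so compound 1 stands level with both. The measured steps are a 1.0-fold lower number from compound 1 to compound 2 (0.01 log units; within the scatter) and a 1.7-fold lower number from compound 1 to compound 3 (0.24 log units; within the scatter) as well as a 1.7-fold lower number from compound 2 to compound 3 (0.23 log units; within the scatter) and each alters only the group on the amine nitrogen in a ring.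

Compound 4 (`C/C=C/C(=O)NCCOc1ccc(Oc2c(-c3ccc(F)cc3)sc3cc(O)ccc23)cc1`) carries 2-(((prop-1-en-1-yl)carbonyl)amino)ethyl in place of 1-((prop-1-en-1-yl)carbonyl)azetidin-3-yl on an oxygen on an aromatic ring. Going by the values given here, no measured step covers this exchange, so the series bears on it only indirectly. The nearest guide is compound 1 with its a 1.7-fold lower number from compound 1 to compound 3 (0.24 log units; within the scatter) which shows that changes within this group have so far stayed small. The expected change is a 1.2-fold lower number from compound 1 to compound 4 (0.07 log units; within the scatter) and no step beyond the scatter is anticipated, with wide margins on both sides. In this assay compound 4 is estimated at 8000 nM with 3000 nM to 20000 nM as the expected range.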

Compound 4, half-maximal inhibitory concentration: 12400 nM
Compound 4: the middle estimate sits 1.6-fold (0.19 log units) below what was measured; low and high end bracket the measured number.
By their numbers in this assay, from the lowest: compounds 3, 2, 1 and 4 (each within the scatter of the next, the first and the last beyond it).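

In this assay, exchanging 1-((prop-1-en-1-yl)carbonyl)azetidin-3-yl for 2-(((prop-1-en-1-yl)carbonyl)amino)ethyl on the oxygen on an aromatic ring gives a 1.3-fold higher number from compound 1 to compound 4 (0.12 log units; within the scatter) and so leaves compound 4 level with compound 1. The earlier steps shown here altered only the group on the amine nitrogen in a ring, whereas this one removes the four-membered ring and adds a hydrogen-bond donor, the amide hydrogen, without a step beyond the scatter. Nothing available explains this result.

Still open, as far as these compounds go, is whether a piperidine ring or a longer chain on this oxygen would hold the same level. Also open, from the compounds shown here alone, is whether 3-((azetidin-1-yl)carbonyl)prop-2-en-1-yl, carried by compound 3, would read the same on the open-chain nitrogen of compound 4.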